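The compounds below may be only part of what the source reports. "The series", "measured", "known", "first", "only" and "open" are said of these compounds alone.

Series notes. Compound 1 `CCSC(=S)SCC(=O)c1ccc(C(=O)N[C@@H](C)c2ccccc2)s1` is the reference point for this step. In a functional assay on HeLa cells (Homo sapiens) for cytotoxicity, read by resazurin assay, with a stated time of 72 h (on this read-out higher numbers stand for weaker inhibition and lower numbers for stronger inhibition), compound 1 gives 15800 nM, the highest of the three numbers in hand. Compound 2 `CCSC(=S)SCC(=O)c1cccc(NC(C)=O)c1` gives 9380 nM in this assay, which sits within the usual scatter of the number for compound 1. Compound 3 `CCNC(=S)SCC(=O)c1ccc(OC)cc1` gives 7800 nM in this assay, a lower number that lies just beyond that scatter. Compound 4 `CCSC(=S)SCC(=O)c1ccc(C(=O)NCc2ccccc2)s1` is not yet measured; it differs from compound 1 by hydrogen in place of methyl on a saturated chain carbon bound to an amide-type nitrogen and an aromatic carbon. Among the compounds with values here, no pair of measured compounds shares this change, so there is nothing to scale it against. The expectation for compound 4 in this assay is a step of a 1.1-fold lower number from compound 1 to compound 4 (0.02 log units; within the scatter), not beyond the scatter in either direction. Compound 4 is therefore estimated at 15000 nM, within 7000 nM to 32000 nM.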

Compound 4, half-maximal inhibitory concentration: 13000 nM
Compound 4: the middle estimate sits 1.2-fold (0.06 log units) above what was measured, within the range that was stated.
By their numbers in this assay, from the lowest: compounds 3, 2, 4 and 1 (each within the scatter of the next, the first and the last beyond it).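

In this assay the change from 1-phenylethyl to benzyl gives a 1.2-fold lower number from compound 1 to compound 4 (0.08 log units; within the scatter) and so stays within the scatter. The methyl on this saturated chain carbon bound to an amide-type nitrogen and an aromatic carbon is therefore not needed to hold the number at this level, at least in this one pair. Nothing at hand bears on why this change leaves the read-out within the scatter. As far as these compounds go, it remains open whether this carbon tolerates anything other than hydrogen or methyl, such as a carboxylic acid or a dimethylamino group. From the compounds shown here alone, it also remains open whether the same change would read alike on the other cores.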